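A third methoxy on the pendant aryl ring

The compounds below may be only part of what the source reports. "The series", "measured", "known", "first", "only" and "open" are said of these compounds alone.

Compound 2 `COc1ccc(C2CC(c3cc(Cl)c(C)cc3O)=NN2c2ccc(S(N)(=O)=O)cc2)cc1OC` carries a 3,4-dimethoxyphenyl group on a saturated ring carbon of the shared core. Among the measured compounds shown here, in a functional assay on SF-268 cells (Homo sapiens) for antiproliferative activity, with a stated time of 48 h (a lower number here means a stronger inhibitor of growth, a higher number a weaker inhibitor of growth), compound 2 gives 100000 nM, the higher of the two values measured so far. For the measured compounds named here, its only neighbour, compound 1 `Cc1cc(O)c(C2=NN(c3ccc(S(N)(=O)=O)cc3)C(/C=C/c3ccccc3)C2)cc1Cl`, bears a 2-phenylethenyl group on that saturated ring carbon, and in this assay compound 1 gives 19500 nM; the step of a 5.1-fold higher number from compound 1 to compound 2 (0.71 log units; beyond the scatter) is the only one recorded. Compound 3 `COc1ccc(C2CC(c3cc(Cl)c(C)cc3O)=NN2c2ccc(S(N)(=O)=O)cc2)c(OC)c1OC` differs from compound 2 by methoxy in place of hydrogen on an aromatic carbon. Going by the values given here, no measured step touches the aryl ring itself, and the one recorded step swaps a whole group, so it cannot say how a further methoxy will behave. The expectation is therefore a change no larger than the scatter, in either direction. Compound 3 is estimated at 100000 nM, within 30000 nM to 200000 nM, so the expected step is no change at the digits printed from compound 2 to compound 3 (within the scatter).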

Compound 3, concentration for total growth inhibition: 34200 nM
The estimate for compound 3 lay 2.9-fold (0.47 log units) above the measured number; measured number inside the range.
By their numbers in this assay, from the lowest: compounds 1 and 3 (each within the scatter of the next); then compound 2.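

In this assay the added methoxy, ortho to a large group and ortho to a methoxy group, gives a 2.9-fold lower number from compound 2 to compound 3 (0.47 log units; beyond the scatter) and so shows that a small addition to the pendant aryl ring itself can move the number beyond the scatter. With a 1.8-fold higher number from compound 1 to compound 3 (0.24 log units; within the scatter) the 2,3,4-trimethoxyphenyl and 2-phenylethenyl groups cannot be told apart, whereas the 3,4-dimethoxyphenyl group stood clearly apart from the 2-phenylethenyl group. Nothing available explains why this extra methoxy lowers the number.

On these data alone, what stays open is whether the effect belongs to this particular aromatic carbon or would appear at other carbons of the ring. As far as these compounds go, it is also open whether a fluorine, an ethoxy or an amine on this same carbon would move the number as methoxy does.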